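The source may hold more compounds than are shown below. What is called first, only, known or untested is meant among the compounds shown, and "the series" means these compounds.

Compound 1 `O=C1O[C@@H](CN2CCC(c3ccc(F)cc3)CC2)CN1c1ccc(-n2cc(-c3ccccn3)cn2)c(F)c1`: 5.78
Compound 2 `O=C1CCC(=O)N1C[C@H]1CN(c2ccc(-n3cc(-c4ccccn4)cn3)c(F)c2)C(=O)O1`: 1.58
Compound 3 `O=C1CNC(=O)N1C[C@H]1CN(c2ccc(-n3cc(-c4ccccn4)cn3)c(F)c2)C(=O)O1`: 1.25

The three measured compounds share one core and differ only in the group carried on a saturated chain carbon bound to a saturated ring carbon. In a physicochemical assay for lipophilicity, read by HPLC, measured as octanol-water partition (on this read-out lower numbers stand for lower lipophilicity and higher numbers for higher lipophilicity), compound 2 stands second highest of the three numbers. Its nearest neighbour is compound 3, reached by a number 0.33 log units lower from compound 2 to compound 3 (beyond the scatter), a swap of one small five-membered ring with two carbonyls for another of the same kind. Going by the values given here, compound 1, which instead carries a much larger group at this position, lies far higher than both, and no direct step to it is tallied here.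

Compound 4 `O=C1O[C@@H](Cn2ccnc2)CN1c1ccc(-n2cc(-c3ccccn3)cn2)c(F)c1` is the next member. Its difference from compound 2 is 1H-imidazol-1-yl in place of 2,5-dioxopyrrolidin-1-yl on a saturated chain carbon bound to a saturated ring carbon. Among the compounds with values here, only the step from compound 2 to compound 3 bears on this change, and it was modest; it also concerned a ring of the same family, whereas the entering imidazole ring is aromatic and carries no double bonds outside aromatic rings. With nothing closer to lean on, only a small shift is expected. For compound 4 in this assay the estimate is 1.8, with a range from 1.1 to 2.6. This expected step of a number 0.22 log units higher from compound 2 to compound 4 (within the scatter) would stay within the usual scatter.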

Compound 4, partition coefficient: 1.73
Estimate against measurement, compound 4: 0.07 log units above; measured number inside the range.
By their numbers in this assay, from the lowest: compound 3; then compounds 2 and 4 (each within the scatter of the next); then compound 1.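

In this assay, the swap of 2,5-dioxopyrrolidin-1-yl for 1H-imidazol-1-yl gives a number 0.15 log units higher from compound 2 to compound 4 (within the scatter) and so leaves the two compounds indistinguishable, even though a five-membered aromatic ring has replaced a non-aromatic ring with 2 double bonds outside aromatic rings. Set against 2,5-dioxoimidazolidin-1-yl, the same entering group gives a number 0.48 log units higher from compound 3 to compound 4 (beyond the scatter) and this is a real but modest separation, so this position can hold quite different small five-membered rings while the numbers stay in a narrow band, far from compound 1 at 5.78 in this assay. Nothing available here offers an explanation for how these rings compare.

The wide gap up to compound 1 remains unfilled, since none of the compounds shown carries a group of intermediate size at this place. Going by these compounds, how a simple open-chain amine, a carboxylic acid or a longer chain would read on a saturated chain carbon bound to a saturated ring carbon remains open, as does whether the narrow band extends beyond five-membered rings.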